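From isoquinolin-5-yl to 4-hydroxyphenyl: compound 3 to compound 4

The compounds below may be only part of what the source reports. "The series", "measured", "known", "first", "only" and "open" are said of these compounds alone.

In a functional assay on BT-549 cells (Homo sapiens) for inhibition, read by sulforhodamine B assay, with a stated time of 6 days (a lower number here means a stronger inhibitor, a higher number a weaker inhibitor), compound 3 `CNCCNCc1cccc(-c2nc(NC3CCOCC3)c(C)c(-c3cccc4cnccc34)n2)c1` gives 32000 nM and compound 1 `CNCCNCc1cccc(-c2nc(NC3CCOCC3)c(C)c(-c3ccnc4[nH]ccc34)n2)c1` gives 25200 nM, the two standing level within the scatter (a 1.3-fold higher number from compound 1 to compound 3 (0.10 log units; within the scatter)). Compound 2 `CNCCNCc1cccc(-c2nc(NC3CCOCC3)c(C)c(-c3cn(C)nc3C)n2)c1` reads > 50000 nM as a limit of the assay and not as a number. Compound 4 `CNCCNCc1cccc(-c2nc(NC3CCOCC3)c(C)c(-c3ccc(O)cc3)n2)c1` carries 4-hydroxyphenyl in place of isoquinolin-5-yl on an aromatic carbon next to the ring nitrogen and ortho to a methyl group (4-hydroxyphenyl in place of isoquinolin-5-yl on an aromatic carbon). The other measured changes at that carbon (an at least 1.9-fold higher number from compound 1 to compound 2 (0.29 log units; that floor lies within the scatter); an at least 1.5-fold lower number from compound 2 to compound 3 (0.19 log units; that floor lies within the scatter)) give only floors within the scatter. With compound 3 level with compound 1 (a 1.3-fold higher number from compound 1 to compound 3 (0.10 log units; within the scatter)) and no change at that carbon shown beyond the scatter, no step beyond the scatter is expected in this assay here. The expected step is a 1.1-fold lower number from compound 3 to compound 4 (0.03 log units; within the scatter) and a reading at the assay limit remains possible. Compound 4 is estimated at 30000 nM with an expected range of 12000 nM to 60000 nM in this series.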

Compound 4, half-maximal inhibitory concentration: 23700 nM
Beside the measured number, compound 4's estimate is 1.3-fold (0.10 log units) above it; the measured number falls inside the stated range.
By their numbers in this assay, from the lowest: compounds 4, 1 and 3 (each within the scatter of the next). At a limit, above all of these: compound 2.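

Compound 4 shows that at this carbon, next to the ring nitrogen and ortho to the methyl group, a 4-hydroxyphenyl with one six-membered aromatic ring stands level in this assay with both groups of two fused rings: a 1.4-fold lower number from compound 3 to compound 4 (0.13 log units; within the scatter) and a 1.1-fold lower number from compound 1 to compound 4 (0.03 log units; within the scatter). Among the compounds shown here, it also gives the only step at this carbon so far that is printed as beyond the scatter, an at least 2.1-fold lower number from compound 2 to compound 4 (0.32 log units; beyond the scatter), and that step is a floor. Compound 2 stands at a limit of the assay and not at a number: the limit of > 50000 nM in this assay, at which 1 of the 4 values shown sits.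

Among the compounds shown, nothing separates the hydroxy group from the benzene ring that carries it, a question that plain phenyl or 4-aminophenyl at this carbon would address. Also open, going by these compounds, is whether any group here, such as a carboxylic acid on that ring, would move the reading well beyond the level of compounds 1, 3 and 4.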